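Compound 1 to Compound 4: a Change at the Saturated Carbon

The source may hold more compounds than are shown below. What is called first, only, known or untested is meant among the compounds shown, and "the series" means these compounds.

Measured compounds:
compound 1, `COc1ncc(-c2ccccc2)cc1[C@@H](c1ccccc1)[C@@](O)(CCN(C)C)c1cccc2ccccc12`: > 50 ug/mL
compound 2, `COc1nc(-c2cnsc2)ccc1[C@@H](c1ccccc1)[C@@](O)(CCN(C)C)c1cccc2ccccc12`: 26.3 ug/mL
compound 3, `COc1nc(-c2ccsc2)ccc1[C@@H](c1ccccc1)[C@@](O)(CCN(C)C)c1cccc2ccccc12`: 24.4 ug/mL

Of the compounds shown here, three with a shared core have been measured in a toxicity assay on Vero cells (Chlorocebus sabaeus) for cytotoxicity; on this read-out higher numbers stand for lower toxicity in this test and lower numbers for higher toxicity in this test. Compound 1 stands at the limit of this test rather than at a number, giving > 50 ug/mL, which is the limit described by the limit of > 50 ug/mL in this assay, at which 1 of the 3 values shown sits. In this assay compound 2 gives 26.3 ug/mL. In this assay compound 3 gives 24.4 ug/mL. Going by the values given here, the only step that connects two measured compounds is a 1.1-fold lower number from compound 2 to compound 3 (0.03 log units; within the scatter).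

Compound 4, `COc1ncc(-c2ccccc2)cc1[C@@H](c1ccccc1)[C@@](O)(CCN(C)C)c1cc(F)ccc1F`, has not been measured. It differs from compound 1 by 2,5-difluorophenyl in place of naphthalen-1-yl on a saturated chain carbon bound to an oxygen on a saturated carbon and two saturated chain carbons. Among the compounds with values here, the one measured step concerns a different place in the molecule and was within the scatter, so it does not bear on this change; no measured step does. With compound 1 at the limit, there is no number to start from, only a floor.

On that basis compound 4 is expected to stand near the same limit, with an estimate of 50 ug/mL and a range from 20 ug/mL to 100 ug/mL. That estimate means a step of a number no higher from compound 1 to compound 4 (the limit leaves the size open), with the chance of another limit being high.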

Compound 4, half-maximal cytotoxic concentration: > 50 ug/mL
Compound 4 was reported as a limit; the forecaster's own chance of this, stated with the estimate: 55%; the middle value sits exactly at the limit.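

In this assay compound 4 gives > 50 ug/mL, which is a limit and not a number. Compound 1 stands at a limit as well, so no step can be read from compound 1 to compound 4: the limit of > 50 ug/mL in this assay, at which 2 of the 4 values shown sit.

The compounds shown leave open whether 2,5-difluorophenyl in place of naphthalen-1-yl changes the result in this assay at all, and in which direction.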